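Adding one more methoxy to compound 2

A few compounds are considered here, and "the series" means these few. Any claim that something is new, unique, unknown or untested is made for them only; others in the source may bear on it.

Three compounds share one core and differ only in their methoxy groups: compound 1 `C=C(Br)C(=O)Nc1ccc(C(=O)/C=C/c2ccc(OC)cc2)cc1`, compound 2 `C=C(Br)C(=O)Nc1ccc(C(=O)/C=C/c2ccc(OC)c(OC)c2)cc1` and compound 3 `C=C(Br)C(=O)Nc1ccc(C(=O)/C=C/c2cc(OC)c(OC)c(OC)c2)cc1`. In a functional assay on FM3A cells (Mus musculus) for antiproliferative activity, with a stated time of 48 h (a higher number here means a weaker inhibitor, a lower number a stronger inhibitor), compound 1 gives 1000 nM, compound 2 gives 1200 nM and compound 3 gives 1800 nM. Compound 2 therefore stands close to both of the others, as the two measured steps show: a 1.2-fold higher number from compound 1 to compound 2 (0.08 log units; within the scatter) and a 1.5-fold higher number from compound 2 to compound 3 (0.18 log units; within the scatter). Each of these steps puts a methoxy in place of hydrogen on an aromatic carbon, and both stay within the usual scatter.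

The unmeasured compound 4 `C=C(Br)C(=O)Nc1ccc(C(=O)/C=C/c2ccc(OC)c(OC)c2OC)cc1` arises from compound 2 by one more such replacement: methoxy in place of hydrogen on an aromatic carbon. The new methoxy is ortho to a large group, ortho to a methoxy group and meta to a methoxy group. For the measured compounds named here, no measured step places a methoxy ortho to a large group, so the two steps are only a loose guide. Compound 4 carries as many methoxy groups as compound 3, which gives 1800 nM, so no change beyond the scatter is expected in this assay. The expected step is a 1.3-fold higher number from compound 2 to compound 4 (0.10 log units; within the scatter). For compound 4 the estimated value is 1500 nM, with an expected range from 700 nM to 3200 nM.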

Compound 4, half-maximal inhibitory concentration: 530 nM
Estimate against measurement, compound 4: 2.8-fold (0.45 log units) above, outside the stated range (below it).
By their numbers in this assay, from the lowest: compounds 4, 1, 2 and 3 (each within the scatter of the next, the first and the last beyond it).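

In this assay, placing a methoxy ortho to a large group, ortho to a methoxy group and meta to a methoxy group gives a 2.3-fold lower number from compound 2 to compound 4 (0.35 log units; beyond the scatter), so this is the only single replacement among these compounds whose step reaches beyond the scatter, and it points towards a stronger inhibitor. The same kind of replacement at a different place on the same ring gives a 1.5-fold higher number from compound 2 to compound 3 (0.18 log units; within the scatter), which stays within the scatter, so in this small set the effect of adding a methoxy to compound 2 depends on where it goes and not merely on its being added. Nothing given here explains why this position differs from the other one.

On these data alone, it remains open whether the gain belongs to the methoxy itself or whether other groups at the same place, such as a hydroxyl, a fluorine, an amine or a longer chain like ethoxy, would lower the number as well. As far as these compounds go, it is also open whether a methoxy at this position would give a similar step on compound 1, which carries one methoxy fewer than compound 2.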